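Two Fluorines on the Amide Side Chain: Expected Toxicity

A few compounds are considered here, and "the series" means these few. Any claim that something is new, unique, unknown or untested is made for them only; others in the source may bear on it.

Measured compounds in a toxicity assay on HepG2 2.2.15 cells (Homo sapiens) for cytotoxicity, read by CCK-8 assay, with a stated time of 8 days; on this read-out lower numbers stand for higher toxicity in this test and higher numbers for lower toxicity in this test:
Compound 1 `CC(C)Cc1nn(-c2nccs2)cc1C(=O)NCc1cccc(F)c1`: compound 1 gives > 100000 nM, a limit of the assay rather than a number.
Compound 2 `CC(C)Cc1nn(-c2nccs2)cc1C(=O)Nc1ccc(F)cc1`: compound 2 gives 83700 nM.
Compound 3 `CC(C)Cc1nn(-c2nccs2)cc1C(=O)NCc1ccc(C(F)(F)F)cc1`: compound 3 gives > 100000 nM, again a limit of the assay.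

Compound 1 therefore stands at the floor of this assay, among the values covered by the limit of > 100000 nM in this assay, at which 2 of the 3 values shown sit, so only a lower bound is known for it. Compound 4 `CC(C)Cc1nn(-c2nccs2)cc1C(=O)NCc1ccc(F)cc1F` differs from compound 1 by 2,4-difluorophenyl in place of 3-fluorophenyl on a saturated chain carbon bound to an amide-type nitrogen. For the measured compounds named here, the only measured single step, an at least 1.1-fold lower number from compound 1 to compound 2 (0.07 log units; that floor lies within the scatter), alters a different part of the molecule and lies within the scatter, so it offers no direction for the change ahead. Compound 4 is therefore expected to remain in the same region as compound 1. The estimate for compound 4 is 100000 nM, with a range from 50000 nM to 300000 nM, which means an expected step of a number no higher from compound 1 to compound 4 (the limit leaves the size open).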

Compound 4, half-maximal cytotoxic concentration: 83600 nM
Beside the measured number, compound 4's estimate is 1.2-fold (0.08 log units) above it; measured number inside the range.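

In this assay, 2,4-difluorophenyl in place of 3-fluorophenyl on this saturated chain carbon gives an at least 1.1-fold lower number from compound 1 to compound 4 (0.07 log units; that floor lies within the scatter). For the compounds shown here, this is the first step at this position, and it shows no change that can be told apart from the scatter. Its true size stays open because compound 1 carries a limit of the assay rather than a number: the limit of > 100000 nM in this assay, at which 2 of the 4 values shown sit.

The compounds shown leave open how the toxicity read-out would respond to a very different group here. An amine or a carboxylic acid in place of the 2,4-difluorophenyl, or a longer chain, could test this.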